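The compounds below may be only part of what the source reports. "The series", "measured", "known", "first", "only" and "open" are said of these compounds alone.

In a functional assay on OVCAR-3 cells (Homo sapiens) for cytotoxicity, read by sulforhodamine B assay (a lower number here means a stronger inhibitor of growth, a higher number a weaker inhibitor of growth), compound 1 `CC1=CC[C@@H]([C@@](C)(O)CCCC(C)(C)NC(=S)N/N=C\c2ccccc2)CC1` gives 6970 nM. Its two measured relatives lie within the scatter of that number: compound 2 `CC1=CC[C@@H]([C@@](C)(O)CCCC(C)(C)NC(=S)N/N=C\c2ccc(O)cc2)CC1` gives 6230 nM and compound 3 `CC1=CC[C@@H]([C@@](C)(O)CCCC(C)(C)NC(=S)N/N=C\c2ccccc2[N+](=O)[O-])CC1` gives 7390 nM. Compound 4 `CC1=CC[C@@H]([C@@](C)(O)CCCC(C)(C)NC(=S)N/N=C\c2cccc([N+](=O)[O-])c2)CC1` has not yet been measured. It differs from compound 1 by a single change, (nitro in place of hydrogen on an aromatic carbon), which turns phenyl into 3-nitrophenyl, with the nitro meta to a large group. Within the data shown here, the closest precedent, also nitro in place of hydrogen on an aromatic carbon, is a 1.1-fold higher number from compound 1 to compound 3 (0.03 log units; within the scatter). Hydroxy in place of hydrogen gave a 1.1-fold lower number from compound 1 to compound 2 (0.05 log units; within the scatter). Both steps are within the scatter, so none beyond it is expected here. The expected step is a 1.0-fold higher number from compound 1 to compound 4 (0.00 log units; within the scatter). Compound 4 is estimated at 7000 nM, with an expected range of 4000 nM to 12000 nM.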

Compound 4, concentration for 50% growth inhibition: 8510 nM
Compound 4: middle estimate off by 1.2-fold (0.08 log units), on the low side, within the range that was stated.
By their numbers in this assay, from the lowest: compounds 2, 1, 3 and 4 (each within the scatter of the next).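

In this assay, among these compounds, nitro placed meta to a large group gives a 1.2-fold higher number from compound 1 to compound 4 (0.09 log units; within the scatter), so this position behaves like the one in compound 3. Exchanging 2-nitrophenyl for 3-nitrophenyl gives a 1.2-fold higher number from compound 3 to compound 4 (0.06 log units; within the scatter), which shows that the place of the nitro on the ring makes no difference beyond the scatter here. Even the largest step among these compounds, a 1.4-fold higher number from compound 2 to compound 4 (0.14 log units; within the scatter), stays within the scatter.

No measurement here offers a reason for these numbers. As far as these compounds go, whether an amine or a carboxylic acid on this ring would give a step beyond the scatter remains open.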